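Azetidinylmethoxy pyridines: 5-substituent and nicotinic binding

The source may hold more compounds than are shown below. What is called first, only, known or untested is meant among the compounds shown, and "the series" means these compounds.

Measured compounds in an assay on brain for binding affinity to Neuronal acetylcholine receptor; alpha4/beta2 (Rattus norvegicus), read by radioligand binding; a lower number here means a stronger inhibitor, a higher number a weaker inhibitor:
compound 1 `Fc1cncc(OC[C@@H]2CCN2)c1`, 0.076 nM
compound 2 `Brc1cncc(OC[C@@H]2CCN2)c1`, 0.18 nM
compound 3 `Nc1cncc(OC[C@@H]2CCN2)c1`, 0.082 nM

Compound 3 stands second highest of the three numbers. Its nearest neighbour is compound 1, the two being within the scatter of each other, as a 1.1-fold higher number from compound 1 to compound 3 (0.03 log units; within the scatter) shows; its furthest is compound 2, with a 2.2-fold lower number from compound 2 to compound 3 (0.34 log units; beyond the scatter).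

Compound 4 `CCCc1cncc(OC[C@@H]2CCN2)c1` differs from compound 3 by a single change: propyl in place of amino on an aromatic carbon.

Among the compounds with values here, no measured step exchanges an amino group for an alkyl chain, so none bears directly on this change. The steps that exist concern the same aromatic carbon: a 2.4-fold higher number from compound 1 to compound 2 (0.37 log units; beyond the scatter), a 2.2-fold lower number from compound 2 to compound 3 (0.34 log units; beyond the scatter) and a 1.1-fold higher number from compound 1 to compound 3 (0.03 log units; within the scatter). Within the data shown here, the only group of more than one heavy atom in the set, bromo, gave the highest number. On that basis a modest rise in this assay is expected for compound 4, of the order of a 3.7-fold higher number from compound 3 to compound 4 (0.56 log units; beyond the scatter).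

Compound 4 is therefore expected to give about 0.3 nM in this assay, within a range of 0.1 nM to 1 nM.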

Compound 4, inhibition constant: 0.039 nM
For compound 4 the middle estimate is 7.7-fold (0.89 log units) above the measured one; the measured number lies below the stated range.
By their numbers in this assay, from the lowest: compounds 4, 1 and 3 (each within the scatter of the next, the first and the last beyond it); then compound 2.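

In this assay this aromatic carbon accepts propyl, the largest group shown here by heavy atoms, with no rise in the number: a 2.1-fold lower number from compound 3 to compound 4 (0.32 log units; beyond the scatter), and a 4.6-fold lower number from compound 2 to compound 4 (0.66 log units; beyond the scatter), while a 1.9-fold lower number from compound 1 to compound 4 (0.29 log units; within the scatter). The number therefore does not follow heavy-atom count across the four compounds: bromo in compound 2 has more heavy atoms than fluoro or amino and gives a higher number, whereas propyl in compound 4 has more still and does not, and the change from amino also removes the hydrogen-bond donor and acceptor without any rise. No measurement shown accounts for these steps.

From the compounds shown here alone, how a longer chain such as pentyl, or a branched one such as isopropyl, would read at this carbon remains open. So does the effect of a carboxylic acid or a phenyl ring there.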